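Removing both substituents from the benzamide ring of compound 2

The compounds below may be only part of what the source reports. "The series", "measured", "known", "first", "only" and "open" are said of these compounds alone.

Compound 2 `COc1cc(-c2nn(-c3cccc(NC(=O)c4ccc(Cl)c(C(F)(F)F)c4)c3)cc2-c2ccncc2)ccc1Cl` carries an amide whose aryl group bears a chlorine and a trifluoromethyl. Going by the values given here, in a functional assay on SK-MEL-5 cells (Homo sapiens) for inhibition, read by sulforhodamine B assay, with a stated time of 48 h (a lower number here means a stronger inhibitor of growth, a higher number a weaker inhibitor of growth), compound 2 gives 1380 nM, and it stands within the scatter of compound 1 `COc1cc(-c2nn(-c3cccc(NC(=O)Nc4ccc(Cl)c(Cl)c4)c3)cc2-c2ccncc2)ccc1Cl`, the only other measured compound, which in this assay gives 741 nM. Among the compounds with values here, the one measured step, a 1.9-fold higher number from compound 1 to compound 2 (0.27 log units; within the scatter), exchanged the whole group on the carbonyl carbon and produced no shift beyond the scatter. Compound 3 `COc1cc(-c2nn(-c3cccc(NC(=O)c4ccccc4)c3)cc2-c2ccncc2)ccc1Cl` differs from compound 2 by phenyl in place of 4-chloro-3-(trifluoromethyl)phenyl on a carbonyl carbon. Within the data shown here, no measured step removes substituents from this ring while keeping the amide, so the available data give no firm direction; the step from compound 1 to compound 2 shows only that a different aryl group here left the number about the same. The step of a 1.8-fold higher number from compound 2 to compound 3 (0.26 log units; within the scatter) is therefore expected to be modest, with a wide range. Compound 3 is estimated to give 2500 nM in this assay, between 800 nM and 8000 nM.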

Compound 3, concentration for 50% growth inhibition: 319 nM
Estimate against measurement, compound 3: 7.8-fold (0.89 log units) above, outside the stated range (below it).
By their numbers in this assay, from the lowest: compound 3; then compounds 1 and 2 (each within the scatter of the next).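

In this assay, the aryl group on the carbonyl carbon now shows a real effect, which the earlier pair within the scatter did not: taking away both substituents gave a 4.3-fold lower number from compound 2 to compound 3 (0.64 log units; beyond the scatter) and so went beyond the scatter. Phenyl in place of the (3,4-dichlorophenyl)amino group gave a 2.3-fold lower number from compound 1 to compound 3 (0.37 log units; beyond the scatter) and also went beyond it, so among these three compounds the unsubstituted ring gives the lowest number and neither larger group is needed for growth inhibition in these cells. Nothing measured here bears on why the number falls with this change.

Going by these compounds alone, it remains open whether the chlorine, the trifluoromethyl or only the pair of them accounts for the higher number of compound 2. Also open, as far as these compounds go, is how this ring would respond to a methoxy group, an amine or a carboxylic acid, and whether a phenylamino group on the same carbonyl carbon would match phenyl.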